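Carboxypyridinyl in Place of Carbamoylphenyl on the Shared Core

The compounds below may be only part of what the source reports. "The series", "measured", "known", "first", "only" and "open" are said of these compounds alone.

Measured so far in an assay (Rattus norvegicus) for inhibition of Fatty-acid amide hydrolase 1 (Homo sapiens); a higher number here means a weaker inhibitor, a lower number a stronger inhibitor:
compound 1 `N#Cc1ccccc1-c1cnc(C(=O)CCCCCCc2ccccc2)o1` gives 130 nM
compound 2 `NC(=O)c1cccc(-c2cnc(C(=O)CCCCCCc3ccccc3)o2)c1` gives 6 nM
compound 3 `COC(=O)c1ccc(-c2cnc(C(=O)CCCCCCc3ccccc3)o2)nc1` gives 3.5 nM

Compound 2 has the second highest of these three numbers. Its nearest neighbour is compound 3, whose value lies within the scatter of that of compound 2, so the two cannot be ordered. Within the data shown here, compound 1 stands far from both, and the only single-point step in the set is a 22-fold lower number from compound 1 to compound 2 (1.34 log units; beyond the scatter), a large step that accompanies the replacement of the 2-cyanophenyl group.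

Compound 4 `O=C(CCCCCCc1ccccc1)c1ncc(-c2ncccc2C(=O)O)o1` has not been measured. It differs from compound 2 in one place: 3-carboxypyridin-2-yl in place of 3-carbamoylphenyl on an aromatic carbon.

Among the measured compounds shown here, no measured step corresponds to this change. The step of a 22-fold lower number from compound 1 to compound 2 (1.34 log units; beyond the scatter) shows that the group on this position of the shared core can move the number a long way, but it pairs two groups that are both absent from compound 4. Compound 3 carries a methyl ester on a pyridyl ring and its value sits within the scatter of compound 2. With an acid in place of an ester or an amide, a modest rise in the number is expected for compound 4, as a 2.5-fold higher number from compound 2 to compound 4 (0.40 log units; beyond the scatter). The estimate for compound 4 in this assay is 15 nM, with a range from 4 nM to 60 nM.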

Compound 4, inhibition constant: > 50 nM
Compound 4: no number, only a limit; the forecaster's own chance of this, stated with the estimate: 3%; at least 3.3-fold (0.52 log units) between middle value and limit.
By their numbers in this assay, from the lowest: compounds 3 and 2 (each within the scatter of the next); then compound 1.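

In this assay compound 4 gives > 50 nM, which is a limit of the assay and not a number: the limit of > 50 nM in this assay, at which 1 of the 4 values shown sits.

Even read as a limit, the result gives this position a second readable step, and its direction is the opposite of the earlier one: 3-carboxypyridin-2-yl in place of 3-carbamoylphenyl brings an at least 8.3-fold higher number from compound 2 to compound 4 (0.92 log units; beyond the scatter). The earlier compounds shown here offered only a 22-fold lower number from compound 1 to compound 2 (1.34 log units; beyond the scatter), so they showed that the group on this aromatic carbon of the shared core can lower the number a long way, whereas compound 4 shows that replacing the 3-carbamoylphenyl group can also raise it beyond the scatter. The step from compound 1 to compound 4 cannot be read, since the limit leaves its size and direction open.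

The compounds shown leave open how far the number of compound 4 lies beyond its limit. They also leave open whether the step follows the carboxylic acid or the ring nitrogen, which enter together; a 3-carboxyphenyl group or a 3-carbamoylpyridin-2-yl group in this place would separate the two.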